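The compounds below may be only part of what the source reports. "The series", "measured", "known", "first", "only" and "open" are said of these compounds alone.

Among the measured compounds shown here, in a functional assay on HepG2 cells (Homo sapiens) for cytotoxicity, read by MTT assay, with a stated time of 48 h (on this read-out higher numbers stand for weaker inhibition and lower numbers for stronger inhibition), compound 3 `CCCCCCCCCCCCCCNC(=O)[C@@H](NC(=O)c1cc2ccccc2o1)[C@@H](C)O` gives 23400 nM, the lowest of the three numbers so far. Compound 1 `CCCCCCCCNC(=O)[C@@H](NC(=O)c1cc2ccccc2o1)[C@@H](C)O` gives 81300 nM and compound 2 `CCCCCCCCCCCCCCNC(=O)[C@@H](NC(=O)c1ccccc1)[C@@H](C)O` gives 54200 nM. Both steps that lead to compound 3, a 3.5-fold lower number from compound 1 to compound 3 (0.54 log units; beyond the scatter) and a 2.3-fold lower number from compound 2 to compound 3 (0.36 log units; beyond the scatter), were modest. Compound 4 `CCCCCCCCCCCCCCNC(=O)[C@@H](NC(=O)c1cc2ccccc2n1C)[C@@H](C)O` differs from compound 3 by 1-methyl-1H-indol-2-yl in place of 1-benzofuran-2-yl on a carbonyl carbon. For the measured compounds named here, no measured step alters this part of the structure in the same way, so the earlier steps bear on it only loosely: they show that single changes have so far moved the number by modest amounts. Compound 4 is therefore expected to give about 18000 nM, with a range from 6000 nM to 55000 nM. The step of a 1.3-fold lower number from compound 3 to compound 4 (0.11 log units; within the scatter) is estimated to stay near the scatter.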

Compound 4, half-maximal inhibitory concentration: 34500 nM
The estimate for compound 4 lay 1.9-fold (0.28 log units) below the measured number, and the stated range covers the measured number.
By their numbers in this assay, from the lowest: compounds 3, 4, 2 and 1 (each within the scatter of the next, the first and the last beyond it).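

In this assay the change from 1-benzofuran-2-yl to 1-methyl-1H-indol-2-yl on the carbonyl carbon gives a 1.5-fold higher number from compound 3 to compound 4 (0.17 log units; within the scatter) and so does not separate the two groups. The change from phenyl to 1-methyl-1H-indol-2-yl gives a 1.6-fold lower number from compound 2 to compound 4 (0.20 log units; within the scatter) and also stays within the scatter, so this position tolerates all three groups with little effect on the number. No measured property is available to explain these results. Still open, on these data alone, is whether 1H-indol-2-yl, without the methyl, behaves the same way. A ring carrying an amine or a carboxylic acid is also untested among these compounds.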